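Amide variation on a dichlorophenyl pyrazole carboxamide

A few compounds are considered here, and "the series" means these few. Any claim that something is new, unique, unknown or untested is made for them only; others in the source may bear on it.

Compound 1 `CC(C)(C)NC(=O)c1cc(-c2ccc(Cl)cc2Cl)n[nH]1`: 398 nM
Compound 2 `O=C(c1cc(-c2ccc(Cl)cc2Cl)n[nH]1)N1CCOCC1`: 574 nM

In an assay on isolated protein for inhibition of alkaline phosphatase, tissue-nonspecific isozyme (Homo sapiens) (on this read-out higher numbers stand for weaker inhibition and lower numbers for stronger inhibition), compound 2 gives the highest of the two numbers; its nearest neighbour is compound 1, and the step of a 1.4-fold higher number from compound 1 to compound 2 (0.16 log units; within the scatter) stays within the scatter. Compound 3 `COCCNC(=O)c1cc(-c2ccc(Cl)cc2Cl)n[nH]1` is not yet measured. It differs from compound 2 by (2-methoxyethyl)amino in place of morpholin-4-yl on a carbonyl carbon. Going by the values given here, the only measured step, from compound 1 to compound 2, changed the amide substituent and moved the number only a little, so a change beyond the scatter is not expected here; a 1.3-fold lower number from compound 2 to compound 3 (0.11 log units; within the scatter) is the estimated step. Compound 3 is expected at 450 nM, in the range 200 nM to 1000 nM.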

Compound 3, half-maximal inhibitory concentration: 46 nM
Beside the measured number, compound 3's estimate is 9.8-fold (0.99 log units) above it; the measured number lies below the stated range.
By their numbers in this assay, from the lowest: compound 3; then compounds 1 and 2 (each within the scatter of the next).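

The amide position, which looked flat between the first two compounds, responds strongly to this change: (2-methoxyethyl)amino in place of morpholin-4-yl on the carbonyl carbon gives a 12-fold lower number from compound 2 to compound 3 (1.10 log units; beyond the scatter) in this assay. The step of 2-methoxyethyl in place of tert-butyl on the amide-type nitrogen gives an 8.7-fold lower number from compound 1 to compound 3 (0.94 log units; beyond the scatter), and as compound 1 also carries the amide hydrogen, that hydrogen alone does not set the number. No available evidence accounts for the gain. Still open, on these data alone, is whether the chain's ether oxygen matters, which a plain propyl chain or a longer 3-methoxypropyl chain on the same nitrogen would test.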